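Swapping the aryl amine on a dimethoxyphenyl urea scaffold

A few compounds are considered here, and "the series" means these few. Any claim that something is new, unique, unknown or untested is made for them only; others in the source may bear on it.

Measured so far:
compound 1 `Cc1cc(F)cc(Nc2cc(NC(=O)Nc3c(Cl)cccc3Cl)ncn2)c1`: 60.5%
compound 2 `COc1cc(NC(=O)Nc2cc(Nc3ccc(F)c(Cl)c3)ncn2)cc(OC)c1`: 25.5%
compound 3 `COc1ccc(Nc2cc(NC(=O)Nc3c(Cl)cccc3Cl)ncn2)cc1C`: 29.1%

In a functional assay on NCI-H520 cells (Homo sapiens) for inhibition, read by MTT assay, with a stated time of 48 h, tested at 10 uM (on this read-out higher numbers stand for more inhibition at the one concentration tested (going by the name of the read-out) and lower numbers for less inhibition), compound 2 gives the lowest of the three numbers; its gap to compound 3 lies within the scatter, while compound 1 stands well above it. Compound 4 `COc1cc(NC(=O)Nc2cc(Nc3cc(C)cc(F)c3)ncn2)cc(OC)c1` differs from compound 2 by 3-fluoro-5-methylphenyl in place of 3-chloro-4-fluorophenyl on a nitrogen on an aromatic ring. Among the compounds with values here, the one measured step that bears on this is a number 31.4 percentage points lower from compound 1 to compound 3 (beyond the scatter), where the 3-fluoro-5-methylphenyl group was the one removed; compound 2 and compound 3 share only their low values. Because of a number 31.4 percentage points lower from compound 1 to compound 3 (beyond the scatter) a rise is expected for compound 4, though the different urea aryl leaves it uncertain. The expected step is a number 16.5 percentage points higher from compound 2 to compound 4 (beyond the scatter). Compound 4 is estimated at 42%, between 22% and 65%.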

Compound 4, a percentage reported as inhibition, at one concentration (the size of the read-out at that concentration, not a potency): 24.5%
Estimate against measurement, compound 4: 17.5 percentage points above, within the range that was stated.
By their numbers in this assay, from the lowest: compounds 4, 2 and 3 (each within the scatter of the next); then compound 1.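

In this assay, the change on the nitrogen gives a number 1 percentage points lower from compound 2 to compound 4 (within the scatter), so on the dimethoxyphenyl urea these two aryl groups cannot be told apart. The 3-fluoro-5-methylphenyl group therefore does not bring a high number on every urea: compound 1 carries it and gives 60.5%, while compound 4 carries it and gives 24.5%. No measured evidence here explains this result. Still open, from the compounds shown here alone, is whether a pyridine ring or a cyclohexyl group on this nitrogen would raise the number on the dimethoxyphenyl urea.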